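Extending the biaryl ether toward an acid: compound 4

The compounds below may be only part of what the source reports. "The series", "measured", "known", "first", "only" and "open" are said of these compounds alone.

In an assay on isolated protein for agonist activity at Bile acid receptor (Homo sapiens), read by AlphaScreen, with a stated time of 30 min (a higher number here means that more compound is needed for the effect, a lower number that less compound is needed), compound 2 `CCOc1cccc(-c2ccc([C@H]3S[C@@H](C)C(=O)Nc4c3c(C)nn4-c3ccccc3C)cc2)c1` gives 3500 nM. Compound 1 `Cc1nn(-c2ccccc2C(C)C)c2c1[C@@H](c1ccc(Oc3ccccc3)cc1)S[C@@H](C)C(=O)N2` gives 1900 nM and compound 3 `Cc1cccc(-n2nc(C)c3c2NC(=O)[C@H](C)S[C@@H]3c2ccc(Oc3ccccc3)cc2)c1` gives 2400 nM; both numbers sit within the scatter of compound 2, so the three compounds are indistinguishable on this assay. For the measured compounds named here, the one measured step, a 1.3-fold higher number from compound 1 to compound 3 (0.10 log units; within the scatter), concerns the group on the aromatic nitrogen and does not touch the place changed here. Compound 4 `Cc1ccccc1-n1nc(C)c2c1NC(=O)[C@H](C)S[C@@H]2c1ccc(Oc2cccc(C(=O)O)c2)cc1` differs from compound 2 by 3-carboxyphenoxy in place of 3-ethoxyphenyl on an aromatic carbon. Going by the values given here, no measured step bears on this change, so the expectation rests on the narrow spread of the three numbers alone. Compound 4 is therefore estimated at 1500 nM, within 400 nM to 6000 nM, a step of a 2.3-fold lower number from compound 2 to compound 4 (0.37 log units; beyond the scatter) expected to stay near the scatter.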

Compound 4, half-maximal effective concentration: "not active" (no number reported)
For compound 4 the study gives words and no number, so the estimate cannot be set against anything.
By their numbers in this assay, from the lowest: compounds 1, 3 and 2 (each within the scatter of the next).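

For the compounds shown here, compound 4 is reported as not active in this assay, without a number, so no step from compound 2 to compound 4 can be read. Nothing shown explains this result. The compounds shown leave open how far 3-carboxyphenoxy and 3-ethoxyphenyl differ in number on this assay.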